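Cyclohexyl in place of 4-methoxyphenyl on the shared core

This account rests on a few compounds, and the source may have more. Where it says the series, first, only, none or still open, it means among the compounds named here.

In an ADME assay on Vero cells (Chlorocebus sabaeus) for cytotoxicity, read by MTT assay, with a stated time of 96 h (on this read-out higher numbers stand for lower toxicity in this test and lower numbers for higher toxicity in this test), compound 3 (`COc1ccc(-c2nc3cc(/C(C)=N/NC(N)=O)ccc3[nH]2)cc1`) has no number, its entry being "not determined" (no result reported) and nothing more. Compound 1 (`C/C(=N\NC(N)=O)c1ccc2[nH]c(-c3ccccc3)nc2c1`) gives > 100000 nM in this assay, which is a limit of the assay. Compound 2 (`C/C(=N\NC(N)=O)c1ccc2[nH]c(-c3ccc(Cl)cc3)nc2c1`) gives > 100000 nM there, again a limit. Going to compound 4 (`C/C(=N\NC(N)=O)c1ccc2[nH]c(C3CCCCC3)nc2c1`) puts cyclohexyl in place of 4-methoxyphenyl on an aromatic carbon. Going by the values given here, the only measured step is a step that the two limits leave unreadable from compound 1 to compound 2, a chloro change that offers no size to carry over. What remains is the limit of > 100000 nM in this assay, at which 2 of the 3 values shown sit, so no step beyond the scatter is expected in this assay, in either direction. Compound 4 is estimated at 100000 nM, with an expected range from 35000 nM to 200000 nM in this assay.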

Compound 4, half-maximal cytotoxic concentration: > 100000 nM
Compound 4: only a limit was reported; the forecaster's own chance of this, stated with the estimate: 70%; the middle value sits exactly at the limit.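

In this assay compound 4 gives > 100000 nM, which is a limit of the assay. No new step can be read from compound 1 or compound 2 to compound 4. The compounds shown leave open how far any of the three lies past this limit, and where compound 3 stands.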